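Carbonyl aryl group changes on the shared core

The compounds below may be only part of what the source reports. "The series", "measured", "known", "first", "only" and "open" are said of these compounds alone.

Measured so far:
Compound 1 `COc1cc(-c2nnc3n2NC(c2ccco2)C(C(=O)c2ccccc2C)S3)cc(OC)c1OC` gives 63000 nM in a functional assay on HepG2 cells (Homo sapiens) for cytotoxicity, read by MTT assay, with a stated time of 48 h; a lower number here means a stronger inhibitor, a higher number a weaker inhibitor.
Compound 2 `COc1cc(-c2nnc3n2NC(c2ccco2)C(C(=O)c2cccc4ccccc24)S3)cc(OC)c1OC` gives 33900 nM in this assay.

Among the compounds with values here, compound 2 stands at the lower of the two numbers, but the single measured step, a 1.9-fold lower number from compound 1 to compound 2 (0.27 log units; within the scatter), lies within the scatter. Compound 3 `COc1ccc(C(=O)C2Sc3nnc(-c4cc(OC)c(OC)c(OC)c4)n3NC2c2ccco2)cc1` carries 4-methoxyphenyl in place of naphthalen-1-yl on a carbonyl carbon. That step is the only one bearing on this carbonyl carbon, and it gave nothing beyond the scatter, so no shift beyond the scatter is expected here either. The step from compound 2 to compound 3 is expected to be a 1.3-fold higher number from compound 2 to compound 3 (0.12 log units; within the scatter). Compound 3 is estimated at 45000 nM in this assay, within 20000 nM to 110000 nM.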

Compound 3, half-maximal inhibitory concentration: > 100000 nM
Compound 3 ended at the assay's limit; the forecaster's own chance of this, stated with the estimate: 15%; middle value at least 2.2-fold (0.34 log units) away from the limit.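

4-methoxyphenyl in place of naphthalen-1-yl gives the first change on this carbonyl carbon beyond the scatter in this assay, an at least 2.9-fold higher number from compound 2 to compound 3 (0.46 log units; beyond the scatter). Against 2-methylphenyl the same group gives an at least 1.5-fold higher number from compound 1 to compound 3 (0.20 log units; that floor lies within the scatter), a floor within the scatter, so compound 3 is not separated from compound 1. Compound 3 stands at a limit of the assay, so both steps are floors: the limit of > 100000 nM in this assay, at which 1 of the 3 values shown sits.

Going by these compounds, whether the step follows the methoxy group or the single aromatic ring stays open. On these data alone, an amine or a carboxylic acid in place of the aryl group on this carbonyl carbon also remains open.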